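The source may hold more compounds than are shown below. What is called first, only, known or untested is meant among the compounds shown, and "the series" means these compounds.

Measured compounds in an assay on HEK-293T cells for antagonist activity at vitamin D3 receptor (Homo sapiens), read by a luciferase reporter, with a stated time of 24 h; on this read-out lower numbers stand for stronger inhibition and higher numbers for weaker inhibition:
compound 1 `CC(C)c1onc(-c2c(Cl)cccc2Cl)c1COc1ccc(-c2nc3ccc(C(=O)O)cc3n2CC(C)(C)C)cc1` gives 861 nM
compound 2 `CC(C)c1onc(-c2c(Cl)cccc2Cl)c1COc1ccc(-c2nc3ccc(C(=O)O)cc3n2C(C)C)cc1` gives 3550 nM
compound 3 `CC(C)c1onc(-c2c(Cl)cccc2Cl)c1COc1ccc(-c2nc3ccc(C(=O)O)cc3n2-c2ccc(F)cc2)cc1` gives 2410 nM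

In this assay compound 3 has the second highest number of the three; the step of a 1.5-fold lower number from compound 2 to compound 3 (0.17 log units; within the scatter) lies within the scatter, whereas a 2.8-fold higher number from compound 1 to compound 3 (0.45 log units; beyond the scatter) is a modest step beyond it. Compound 4 `CC(=O)N1CCC(n2c(-c3ccc(OCc4c(-c5c(Cl)cccc5Cl)noc4C(C)C)cc3)nc3ccc(C(=O)O)cc32)CC1` differs from compound 3 by 1-acetylpiperidin-4-yl in place of 4-fluorophenyl on an aromatic nitrogen. Every measured step changes the group on this same aromatic nitrogen: a 4.1-fold higher number from compound 1 to compound 2 (0.62 log units; beyond the scatter), a 2.8-fold higher number from compound 1 to compound 3 (0.45 log units; beyond the scatter) and a 1.5-fold lower number from compound 2 to compound 3 (0.17 log units; within the scatter). None of them covers a 1-acetylpiperidin-4-yl, and all of them stayed modest. Compound 4 is therefore expected to land near compound 3, with a step of a 1.1-fold lower number from compound 3 to compound 4 (0.04 log units; within the scatter) that should stay within the scatter. The estimate for compound 4 is 2200 nM, with a range from 700 nM to 7000 nM.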

Compound 4, half-maximal inhibitory concentration: > 10000 nM
Compound 4: only a limit was reported; the forecaster's own chance of this, stated with the estimate: 10%; middle value at least 4.5-fold (0.65 log units) from the limit.
By their numbers in this assay, from the lowest: compound 1; then compounds 3 and 2 (each within the scatter of the next). At a limit, above all of these: compound 4.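

Compound 4 gives a limit of the assay, not a number: the limit of > 10000 nM in this assay, at which 1 of the 4 values shown sits. Even so, the group on this aromatic nitrogen clearly moves the read-out further than the modest earlier steps did: an at least 4.1-fold higher number from compound 3 to compound 4 (0.61 log units; beyond the scatter), an at least 2.8-fold higher number from compound 2 to compound 4 (0.44 log units; beyond the scatter) and an at least 11-fold higher number from compound 1 to compound 4 (1.06 log units; beyond the scatter). 1-Acetylpiperidin-4-yl is also the only group in this set with a ring hetero atom and a hydrogen-bond acceptor.

Which part of 1-acetylpiperidin-4-yl accounts for the step stays open, since neither a cyclohexyl group nor the free piperidine amine is among the compounds shown. How far compound 4 lies past its limit also cannot be told.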